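The source may hold more compounds than are shown below. What is called first, only, known or untested is meant among the compounds shown, and "the series" means these compounds.

Measured so far:
- Compound 1, `COc1ccc([C@H](O)[C@H]2CO[C@@H](c3ccc(OC)c(OC)c3)[C@H](C/C=C/c3ccccc3)C2)cc1OC`, in a functional assay on HeLa cells (Homo sapiens) for cytotoxicity, read by WST assay, with a stated time of 48 h (on this read-out higher numbers stand for weaker inhibition and lower numbers for stronger inhibition), compound 1 gives 16100 nM.
- Compound 2, `O[C@@H](c1ccccc1)[C@H]1CO[C@H](c2ccccc2)[C@@H](C/C=C/c2ccccn2)C1`, in this assay compound 2 gives 33800 nM.

Of these two numbers, compound 2 has the higher one, which here means the weaker inhibition; the gap to compound 1 lies beyond the usual scatter of repeated measurements, so compound 2 is the weaker of the pair.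

Compound 3, `O[C@@H](c1ccccc1)[C@H]1CO[C@H](c2ccccc2)[C@@H](C/C=C/c2ccc(F)cc2)C1`, has not yet been measured. It differs from compound 2 in a single place:

4-fluorophenyl in place of pyridin-2-yl on a double-bonded chain carbon bound to a double-bonded chain carbon

Among the compounds with values here, no measured pair shows this exact change on the shared core, so the expected step in this assay from compound 2 to compound 3 is uncertain. A modest move towards stronger inhibition seems most likely, as in a 1.7-fold lower number from compound 2 to compound 3 (0.23 log units; within the scatter), though a step within the scatter cannot be ruled out. Compound 3 is therefore expected to give about 20000 nM, with a plausible range from 7000 nM to 60000 nM.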

Compound 3, half-maximal inhibitory concentration: 8340 nM
Estimate against measurement, compound 3: 2.4-fold (0.38 log units) above, and the stated range covers the measured number.
By their numbers in this assay, from the lowest: compounds 3 and 1 (each within the scatter of the next); then compound 2.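

In this assay the ring at the end of the unsaturated chain clearly matters: 4-fluorophenyl in place of pyridin-2-yl gives a 4.1-fold lower number from compound 2 to compound 3 (0.61 log units; beyond the scatter) and thus stronger inhibition. Compound 1 and compound 2 differ in more than one place and could not single out this position, whereas this pair changes only the ring on the double-bonded chain carbon. The change removes a ring nitrogen and adds a fluorine at once, and nothing measured here separates the two or accounts for the step.

Still open, going by these compounds, is how a 4-chlorophenyl or a 4-methoxyphenyl on the same chain carbon would compare, and whether a plain phenyl there on this core would fall nearer compound 2 or compound 3. This single step also cannot tell whether the same change would act alike on the core of compound 1.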